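Chloro for fluoro on the phenoxy arm of compound 2

The source may hold more compounds than are shown below. What is called first, only, known or untested is meant among the compounds shown, and "the series" means these compounds.

Measured so far in an assay on HEK293 cells for inhibition of Voltage-dependent T-type calcium channel subunit alpha-1G (Homo sapiens), read by patch clamp, tested at 10 uM; on this read-out higher numbers stand for more inhibition at the one concentration tested (going by the name of the read-out) and lower numbers for less inhibition:
compound 1, `COc1ccccc1N1CCN(C[C@H](O)COc2ccc(Cl)cc2)CC1`, gives 48.8%
compound 2, `COc1ccccc1N1CCN(C[C@@H](O)COc2ccc(F)cc2)CC1`, gives 50.7%

Two compounds carry numbers, and they lie within the usual scatter of each other, so neither can be placed ahead of the other. Compound 2 stands at 50.7% in this assay, and compound 1, with its chloro group and the other configuration at the alcohol carbon, sits within the scatter of that figure. Among the measured compounds shown here, the two differ in more than one place, so the pair yields no single step to lean on.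

Compound 3, `COc1ccccc1N1CCN(C[C@@H](O)COc2ccc(Cl)cc2)CC1`, is not yet measured. It differs from compound 2 as follows: chloro in place of fluoro on an aromatic carbon. Compound 1, which already carries the chloro group, reads within the scatter of compound 2, so no shift beyond the scatter is looked for here. The expected step of a number 0.3 percentage points higher from compound 2 to compound 3 (within the scatter) is therefore small, in no clear direction. For compound 3 in this assay the estimate is 51%, with a range from 36% to 66%.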

Compound 3, a percentage reported as inhibition, at one concentration (the size of the read-out at that concentration, not a potency): 47.4%
For compound 3 the middle estimate is 3.6 percentage points above the measured one, within the range that was stated.
By their numbers in this assay, from the lowest: compounds 3, 1 and 2 (each within the scatter of the next).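

In this assay, chloro in place of fluoro on an aromatic carbon, para to a large group, can now be read as a single change and amounts to a number 3.3 percentage points lower from compound 2 to compound 3 (within the scatter), so on this read-out the two groups cannot be told apart at this position. With the chloro group in place, the configuration at the alcohol carbon amounts to a number 1.4 percentage points lower from compound 1 to compound 3 (within the scatter), so the drawn stereocentre also leaves the read-out inside the scatter. This second step can be taken as one of configuration alone: the fact that compounds 1 and 3 differ only in the configuration as drawn

The compounds shown leave open whether a different group at this position, such as an amine, a nitrile or a carboxylic acid, would move the read-out beyond the scatter. Also open, on these data alone, are whether configuration counts equally with fluoro in place and how these compounds compare in potency, since a reading at one concentration gives none.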